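This account rests on a few compounds, and the source may have more. Where it says the series, first, only, none or still open, it means among the compounds named here.

Measured in a physicochemical assay for solubility, read by HPLC, in phosphate buffer, at pH 6.8; a higher number here means a more soluble compound, a lower number a less soluble compound:
- Compound 1 `CC(=O)N1CCN(C(=O)[C@@H]2CC[C@@H](C)N2C(=O)C2=C(C(C)C)N3C(=N[C@@](C)(c4ccc(Cl)cc4)[C@H]3c3ccc(Cl)cc3)S2)C[C@@H]1C`: 75 ug/mL
- Compound 2 `CC[C@@H]1CC[C@@H](C(=O)N2CCN(C)[C@H](C)C2)N1C(=O)C1=C(C(C)C)N2C(=N[C@@](C)(c3ccc(Cl)cc3)[C@H]2c2ccc(Cl)cc2)S1`: 14 ug/mL

Compound 2 has the lower number of the two, and its gap to compound 1 lies beyond the usual scatter. Compound 3 `CC[C@@H]1CC[C@@H](C(=O)N2CCN(C(C)=O)[C@@H](C)C2)N1C(=O)C1=C(C(C)C)N2C(=N[C@@](C)(c3ccc(Cl)cc3)[C@H]2c2ccc(Cl)cc2)S1` has not yet been measured. Its difference from compound 2 is a group of 10 heavy atoms (7 carbon, 2 nitrogen, 1 oxygen; one six-membered non-aromatic ring with 2 hetero atoms) in place of a group of 8 heavy atoms (6 carbon, 2 nitrogen; one six-membered non-aromatic ring with 2 hetero atoms), on a carbonyl carbon. Within the data shown here, no measured pair differs in only one place, so any forecast is uncertain. The entering group resembles the matching group of compound 1, which gives 75 ug/mL, so a moderate rise beyond the scatter is expected in this assay. The estimated change is a 2.9-fold higher number from compound 2 to compound 3 (0.46 log units; beyond the scatter). The expected value for compound 3 is 40 ug/mL, within an estimated range of 14 ug/mL to 110 ug/mL.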

Compound 3, solubility: 24 ug/mL
Estimate against measurement, compound 3: 1.7-fold (0.22 log units) above, within the range that was stated.
By their numbers in this assay, from the lowest: compounds 2 and 3 (each within the scatter of the next); then compound 1.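

In this assay, putting the entering ring group in place of 3,4-dimethylpiperazin-1-yl on the carbonyl carbon gives a 1.7-fold higher number from compound 2 to compound 3 (0.23 log units; within the scatter) and so shows no clear effect at this position. By contrast, methyl in place of hydrogen on a saturated chain carbon bound to a saturated ring carbon gives a 3.1-fold lower number from compound 1 to compound 3 (0.49 log units; beyond the scatter) and is the step that clearly separates these two compounds. No measurement here explains either step. From the compounds shown here alone, it remains open how a longer chain, such as propyl, would behave on that chain carbon, or how a carboxylic acid would behave on the piperazine ring.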